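Nitro replaces methoxy on the aryl of compound 3

The source may report more compounds than this note shows. Statements on the series, on what has been measured and on what is new or still open speak of the compounds shown alone.

Of the compounds shown here, three sharing one core have been measured so far. Compound 1 `Cc1c(C(=O)Nc2ccc(C(F)(F)F)cc2)cnn1-c1ccc(F)c(Cl)c1` gives 1300 nM in a functional assay with Homo sapiens as the target; on this read-out higher numbers stand for weaker inhibition and lower numbers for stronger inhibition. Compound 2 `Cc1c(C(=O)Nc2ccc(C(F)(F)F)cc2)cnn1Cc1ccc(F)cc1` gives 3600 nM in this assay. Compound 3 `COc1ccc(-n2ncc(C(=O)Nc3ccc(C(F)(F)F)cc3)c2C)cc1` gives 340 nM in this assay, the lowest of the three numbers and thus the strongest inhibitor of the set, since a 3.8-fold lower number from compound 1 to compound 3 (0.58 log units; beyond the scatter) and an 11-fold lower number from compound 2 to compound 3 (1.02 log units; beyond the scatter) both lie beyond the scatter.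

Compound 4 `Cc1c(C(=O)Nc2ccc(C(F)(F)F)cc2)cnn1-c1ccc([N+](=O)[O-])cc1` has not yet been measured. It differs from compound 3 in one place: nitro in place of methoxy on an aromatic carbon.

Within the data shown here, no measured step changes this very group. Among the measured compounds shown here, the steps that bear on it are those that alter the group on the aromatic nitrogen: a 2.8-fold higher number from compound 1 to compound 2 (0.44 log units; beyond the scatter) and a 3.8-fold lower number from compound 1 to compound 3 (0.58 log units; beyond the scatter), both modest, and an 11-fold lower number from compound 2 to compound 3 (1.02 log units; beyond the scatter), which is large. They show that what hangs on the aromatic nitrogen moves the number, but give no direct reading on nitro against methoxy. A modest step in this assay is therefore expected, more likely toward a higher number than toward a lower one, and a step within the scatter cannot be excluded. For compound 4 the estimate is 700 nM, with a range from 250 nM to 2500 nM, meaning an expected 2.1-fold higher number from compound 3 to compound 4 (0.31 log units; beyond the scatter).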

Compound 4, half-maximal inhibitory concentration: 5700 nM
The estimate for compound 4 lay 8.1-fold (0.91 log units) below the measured number, and the stated range ends below it.
By their numbers in this assay, from the lowest: compound 3; then compound 1; then compounds 2 and 4 (each within the scatter of the next).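

In this assay, among these compounds, nitro in place of methoxy gives a 17-fold higher number from compound 3 to compound 4 (1.22 log units; beyond the scatter) and so provides the first reading of a change on the aromatic carbon para to a large group, showing that this one exchange produces a large step, as does the change on the aromatic nitrogen that gives an 11-fold lower number from compound 2 to compound 3 (1.02 log units; beyond the scatter). The earlier compounds shown here placed both phenyl compounds at lower numbers than the 4-fluorobenzyl compound, but compound 4 goes against that pattern: 4-nitrophenyl gives a 4.4-fold higher number from compound 1 to compound 4 (0.64 log units; beyond the scatter) and, against 4-fluorobenzyl, a 1.6-fold higher number from compound 2 to compound 4 (0.20 log units; within the scatter), which lies within the scatter, so a phenyl on the aromatic nitrogen does not by itself bring a low number. Nothing shown here accounts for the step from methoxy to nitro.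

With only methoxy and nitro compared at this place, the compounds leave open where an amine, a hydroxyl, a nitrile or a chlorine would fall in this assay. They also leave open whether methoxy can be extended to ethoxy with the number staying near that of compound 3, and whether the nitro group would give a similar step elsewhere on the ring.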